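Adding a Methoxy Group to a Cytotoxic Amide

The source may hold more compounds than are shown below. What is called first, only, known or untested is meant among the compounds shown, and "the series" means these compounds.

Of the compounds shown here, three with a shared core have been tested. Compound 1 `COc1ccc(-c2ccc(C(=O)Nc3ccc(Oc4ccnc5[nH]ccc45)cc3)nc2)cc1` gives, in a functional assay on A549 cells (Homo sapiens) for cytotoxicity, read by MTT assay, with a stated time of 72 h (a lower number here means a stronger inhibitor, a higher number a weaker inhibitor), > 10000 nM, which is a limit of the assay and not a number. Compound 2 `Cc1ccc(-c2ccnc(C(=O)Nc3ccc(Oc4ccnc5[nH]ccc45)cc3)c2)cc1` likewise gives > 10000 nM in this assay, again only a limit. For the measured compounds named here, compound 3 `O=C(Nc1ccc(Oc2ccnc3[nH]ccc23)c(F)c1)c1ccc(-c2ccccc2)cn1` is the single compound with a measured number, 1250 nM in this assay; the two other results sit at the limit of > 10000 nM in this assay, at which 2 of the 3 values shown sit.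

Compound 4 `COc1ccc(-c2ccc(C(=O)Nc3ccc(Oc4ccnc5[nH]ccc45)c(F)c3)nc2)cc1` has not yet been measured. It differs from compound 3 by methoxy in place of hydrogen on an aromatic carbon. Going by the values given here, no pair of measured compounds isolates this change, so its effect must be judged from the surrounding results. Compound 1, which carries the same methoxy group, gives only a limit of > 10000 nM in this assay. On that basis the step from compound 3 to compound 4 is expected to be a 3.2-fold higher number from compound 3 to compound 4 (0.51 log units; beyond the scatter), toward weaker inhibition and beyond the usual scatter. Compound 4 is therefore estimated at 4000 nM, within a range of 1500 nM to 15000 nM, with a real chance that only a limit is reported.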

Compound 4, half-maximal inhibitory concentration: 2240 nM
Compound 4: middle estimate off by 1.8-fold (0.25 log units), on the high side, within the range that was stated.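

With the fluoro present, going from phenyl to 4-methoxyphenyl para to a large group gives a 1.8-fold higher number from compound 3 to compound 4 (0.25 log units; within the scatter), so in this assay the two compounds cannot be told apart and the methoxy group is tolerated at this position. The fluoro step gives an at least 4.4-fold lower number from compound 1 to compound 4 (0.64 log units; beyond the scatter), so the same methoxy group can go with a measured number when the fluoro is present. Compound 1, without the fluoro, gives only a limit and not a number: the limit of > 10000 nM in this assay, at which 2 of the 4 values shown sit.

The compounds shown do not tell whether the fluoro has a similar effect on a plain phenyl compound without the methoxy group. They also leave open how an amine or a carboxylic acid in place of the methoxy group would behave at this position.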